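A few compounds are considered here, and "the series" means these few. Any claim that something is new, unique, unknown or untested is made for them only; others in the source may bear on it.

Series notes. Going by the values given here, in a functional assay on BJAB cells (Homo sapiens) for antiproliferative activity, with a stated time of 4 days (on this read-out higher numbers stand for an effect only at larger amounts of compound and lower numbers for an effect already at smaller amounts), three compounds carry numbers so far. Compound 1 `CCSc1sc(-n2nc(C)c(Cc3ccccc3[N+](=O)[O-])c2C(=O)O)nc1-c1ccc(Cl)c(Cl)c1` gives 59000 nM. Compound 2 `Cc1ccccc1-c1c(C)nn(-c2nc(-c3ccc(Cl)c(Cl)c3)c(SC(C)C)s2)c1C(=O)O` gives 5500 nM, the second highest of the three. Compound 3 `Cc1c(-c2cc(Cl)cc(Cl)c2)c(C(=O)O)nn1-c1nc(-c2cc(Cl)cc(Cl)c2)c(SC(C)C)s1` gives 2000 nM, the nearest number to compound 2 and beyond the scatter below it; compound 1 sits furthest from compound 2, with the highest number of the three, also beyond the scatter.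

The next compound, compound 4 `COc1cc(-c2c(C)nn(-c3nc(-c4ccc(Cl)c(Cl)c4)c(SC(C)C)s3)c2C(=O)O)cc(C(F)(F)F)c1`, has not yet been measured in this assay. Its change from compound 2 is 3-methoxy-5-(trifluoromethyl)phenyl in place of 2-methylphenyl on an aromatic carbon. Among the compounds with values here, no measured pair in this set differs in exactly one place, so no step of this kind has been observed directly. The direction rests only on compound 3, whose 2000 nM shows that a different aryl group at this place can go with a lower number than compound 2. For compound 4 the expected step of a 2.2-fold lower number from compound 2 to compound 4 (0.34 log units; beyond the scatter) is modest and towards a lower number, though a result within the scatter of compound 2 would not be surprising. Compound 4 is therefore estimated at 2500 nM, with a range from 800 nM to 8000 nM.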

Compound 4, half-maximal effective concentration: 1380 nM
Beside the measured number, compound 4's estimate is 1.8-fold (0.26 log units) above it, within the range that was stated.
By their numbers in this assay, from the lowest: compounds 4 and 3 (each within the scatter of the next); then compound 2; then compound 1.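

In this assay, going by these compounds alone, this pair gives the first direct reading at the aromatic carbon next to the ring atom that bears a carboxy group: a 4.0-fold lower number from compound 2 to compound 4 (0.60 log units; beyond the scatter). With the rest of compound 2 held constant, the number therefore responds to the aryl group at this place, and 3-methoxy-5-(trifluoromethyl)phenyl, with 12 heavy atoms against 7 and 1 hydrogen-bond acceptor against 0, goes with the lower number. No measurement available here accounts for the step.

The change removes the methyl of 2-methylphenyl and adds methoxy and trifluoromethyl together, so the compounds shown do not separate the contribution of each. Also open, on these data alone, is how the number would respond to an amine or a nitrile on this aryl ring, or to cyclohexyl in place of the aryl group.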